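A few compounds are considered here, and "the series" means these few. Any claim that something is new, unique, unknown or untested is made for them only; others in the source may bear on it.

In a functional assay on the whole organism with Rattus norvegicus as the target (a higher number here means that more compound is needed for the effect, a lower number that less compound is needed), compound 1 `CCOC(=O)C(=O)Nc1cccc(OC)c1C#N` gives 55.5 mg/kg, while compound 2 `CCOC(=O)C(=O)Nc1cccc(N(C)CC)c1C#N` gives 0.5 mg/kg, the lower of the two numbers, so less of compound 2 is needed for the effect. Placing ethyl(methyl)amino where methoxy stood on an aromatic carbon brings a 110-fold lower number from compound 1 to compound 2 (2.05 log units; beyond the scatter), a large step well beyond the scatter.

Within the data shown here, compound 3 `CCOC(=O)C(=O)Nc1cccc(N(CC)CC)c1C#N` keeps the core of compound 2 and alters only that amino group: methyl in place of hydrogen on a saturated chain carbon bound to a nitrogen on an aromatic ring. Methyl takes the place of hydrogen on a saturated chain carbon bound to a nitrogen on an aromatic ring, which turns ethyl(methyl)amino into diethylamino.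

Among the measured compounds shown here, the single measured step bears on this only loosely, since it exchanged a whole group, whereas the new change is much smaller and leaves the nitrogen on the aromatic ring in place. For the measured compounds named here, no measured pair shows what lengthening this chain does, so the expectation is uncertain and stays anchored to compound 2 at 0.5 mg/kg. The expected step is a 1.2-fold higher number from compound 2 to compound 3 (0.08 log units; within the scatter), which is none beyond the scatter. For compound 3 the estimated value in this assay is 0.6 mg/kg, within an expected range from 0.15 mg/kg to 2 mg/kg.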

Compound 3, dose for half-maximal effect: 0.9 mg/kg
Compound 3: the middle estimate sits 1.5-fold (0.18 log units) below what was measured, and the stated range covers the measured number.
By their numbers in this assay, from the lowest: compounds 2 and 3 (each within the scatter of the next); then compound 1.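

Turning ethyl(methyl)amino into diethylamino gives a 1.8-fold higher number from compound 2 to compound 3 (0.26 log units; within the scatter) in this assay, so the added methyl, on a saturated chain carbon bound to a nitrogen on an aromatic ring, makes no difference that can be told from the scatter. The large drop seen earlier also holds for a second amino group: diethylamino in place of methoxy gives a 62-fold lower number from compound 1 to compound 3 (1.79 log units; beyond the scatter), which shows that the drop is not tied to ethyl(methyl)amino alone, although only these two amino groups can be compared with methoxy so far. Nothing available gives a reason for either step.

On these data alone, what a plain amino group, a pyrrolidine ring or a longer chain such as propyl on that nitrogen would do remains open, so it is unclear how far this tolerance for small changes extends. Also open is how much the ethyl ester and the nitrile contribute to the effect, as both stay the same in all the compounds shown.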